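The source may report more compounds than this note shows. Statements on the series, on what has been measured and on what is new or still open speak of the compounds shown alone.

Among the measured compounds shown here, compound 1 `C=C1[C@@H](OC(C)=O)C[C@@H]2[C@](C)(CO[Si](C)(C)C(C)(C)C)[C@H](OC(C)=O)CC[C@@]2(C)[C@@H]1C[C@@H](Nc1cccc(F)c1)C1=CCOC1=O` stands lowest of the two numbers measured so far: in a functional assay on MCF7 cells (Homo sapiens) for cytotoxicity, read by sulforhodamine B assay (a higher number here means a weaker inhibitor, a lower number a stronger inhibitor), compound 1 gives 3820 nM. Compound 2 `C=C1[C@@H](OC(C)=O)C[C@@H]2[C@](C)(COC=O)[C@H](OC(C)=O)CC[C@@]2(C)[C@@H]1C[C@@H](Nc1cccc2ccccc12)C1=CCOC1=O` gives 9750 nM in this assay, a gap beyond the usual scatter. Compound 3 `C=C1[C@@H](OC(C)=O)C[C@@H]2[C@](C)(CO[Si](C)(C)C(C)(C)C)[C@H](OC(C)=O)CC[C@@]2(C)[C@@H]1C[C@@H](Nc1ccc(F)cc1)C1=CCOC1=O` shares the core of compound 1 and differs in a single group: 4-fluorophenyl in place of 3-fluorophenyl on an amine nitrogen. For the measured compounds named here, no measured pair shows this change, so its effect is unknown. The step is expected to be small, within the scatter, with no clear direction: a 1.2-fold higher number from compound 1 to compound 3 (0.07 log units; within the scatter). For compound 3 the expected value in this assay is 4500 nM, in a range from 1800 nM to 11000 nM.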

Compound 3, half-maximal inhibitory concentration: 4340 nM
For compound 3 the middle estimate is 1.0-fold (0.02 log units) above the measured one, and the stated range covers the measured number.
By their numbers in this assay, from the lowest: compounds 1 and 3 (each within the scatter of the next); then compound 2.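

Among the compounds shown here, with this assay, 4-fluorophenyl in place of 3-fluorophenyl on the amine nitrogen gives a 1.1-fold higher number from compound 1 to compound 3 (0.06 log units; within the scatter), the first comparison that changes only this group. Compound 1 and compound 3 cannot be told apart, so this change in the fluorine's place on the ring makes no measurable difference here. Nothing measured here offers an explanation for this result. Still open, going by these compounds, is whether plain phenyl or 4-methoxyphenyl on this nitrogen would give a number beyond the scatter from compound 1. Compound 2 differs from compound 1 in more than one place, so it cannot settle this.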